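Swapping One Aromatic Group on Compound 1

The compounds below may be only part of what the source reports. "The series", "measured", "known", "first", "only" and "open" are said of these compounds alone.

Values from an ADME assay on microsomes from liver (Mus musculus) for metabolic stability (a higher number here means that the compound lasts longer, a lower number that the compound disappears faster), are these
compound 1 `O=C(O)c1cc(F)c2nc(N3CCC4(C=C(c5c(-c6ccccc6C(F)(F)F)noc5C5CC5)C4)CC3)sc2c1` gives > 2 h as a limit of the assay
compound 2 `O=C(O)c1ccc2cc(N3CCC4(C=C(c5c(-c6c(Cl)cc(F)cc6Cl)noc5C5CC5)C4)CC3)ccc2n1` gives 1.48 h as a measured half-life
compound 3 `O=C(O)c1cc(F)c2nc(N3CCC(CCc4c(-c5c(Cl)cccc5Cl)noc4C4CC4)CC3)sc2c1` gives 0.283 h as a measured half-life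

In this assay compound 1 gives > 2 h and that is a limit, not a number. It therefore stands at the limit of > 2 h in this assay, at which 1 of the 3 values shown sits, and has no exact half-life to start from.

In compound 4 `O=C(O)c1cc(F)c2nc(N3CCC4(C=C(c5c(-c6c(Cl)cncc6Cl)noc5C5CC5)C4)CC3)sc2c1` the 2-(trifluoromethyl)phenyl of compound 1 gives way to 3,5-dichloropyridin-4-yl on an aromatic carbon of a five-membered aromatic ring with 1 nitrogen and 1 oxygen (3,5-dichloropyridin-4-yl in place of 2-(trifluoromethyl)phenyl on an aromatic carbon). The rest of the structure stays the same.

Going by the values given here, no two measured compounds differ in one place only, so the data give no direct size for this change. Compound 2 (1.48 h) and compound 3 (0.283 h) both carry chlorine on an aromatic group, yet their values lie far apart and set no firm direction.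

The expected step is an at least 1.1-fold lower number from compound 1 to compound 4 (0.04 log units; that floor lies within the scatter) and it should be a modest fall or none beyond the scatter. For compound 4 the half-life is estimated at 1.8 h in this assay with an expected range from 0.8 h to 4 h as its ends.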

Compound 4, half-life: > 2 h
Compound 4 was reported as a limit; the forecaster's own chance of this, stated with the estimate: 45%; middle value at least 1.1-fold (0.04 log units) away from the limit.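

In this assay compound 4 gives > 2 h, which is a limit of the assay and not a number. Going by these compounds alone, compound 1 gives > 2 h, also a limit, and no step from compound 1 to compound 4 can be read; both stand at the same limit: the limit of > 2 h in this assay, at which 2 of the 4 values shown sit. The compounds shown leave open whether 3,5-dichloropyridin-4-yl in place of 2-(trifluoromethyl)phenyl changes the half-life at all.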